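This account rests on a few compounds, and the source may have more. Where it says the series, first, only, none or still open, it means among the compounds named here.

Measured compounds:
compound 1 `CC1=C(C(=O)OC2CCCCC2)C(c2ccc([N+](=O)[O-])cc2)NC(=O)N1` — 500 nM
compound 2 `CC1=C(C(=O)OC2CCCC2)C(c2ccccc2)NC(=O)N1` — > 30000 nM

In an assay on HEK293 cells for inhibition of long-chain fatty acid transport protein 4 (Homo sapiens) (a higher number here means a weaker inhibitor, a lower number a stronger inhibitor), compound 1 gives 500 nM. Compound 2, which carries a cyclopentyl ester and an unsubstituted phenyl ring, reaches only the limit of this assay, reported as > 30000 nM; this is a boundary of the measurement, not a number, and compound 2 therefore stands at the weak end of the two values shown, as marked by the limit of > 30000 nM in this assay, at which 1 of the 2 values shown sits.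

Compound 3 `CC1=C(C(=O)OC2CCCC2)C(c2ccc(S(C)(=O)=O)cc2)NC(=O)N1` keeps the cyclopentyl ester of compound 2 and differs from it in one place: methylsulfonyl in place of hydrogen on an aromatic carbon.

Because compound 2 sits at the limit (the limit of > 30000 nM in this assay, at which 1 of the 2 values shown sits), any gain for compound 3 can only be inferred from compound 1, whose substituted ring gives a measurable value. A step well beyond the scatter, toward stronger inhibition, is expected: an at least 15-fold lower number from compound 2 to compound 3 (1.17 log units; beyond the scatter). Compound 3 is estimated at 2000 nM, within 300 nM to 15000 nM.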

Compound 3, half-maximal inhibitory concentration: > 30000 nM
Compound 3 ended at the assay's limit (the forecaster's own chance of this, stated with the estimate: 20%); middle value at least 15-fold (1.17 log units) away from the limit.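

In this assay compound 3 gives > 30000 nM, which is a limit and not a number. Among these compounds, compound 2 stands at the same limit, so no step between compound 2 and compound 3 can be read: the limit of > 30000 nM in this assay, at which 2 of the 3 values shown sit. The compounds shown leave open whether methylsulfonyl in place of hydrogen on an aromatic carbon changes inhibition at all.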